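Swapping isopropyl for chloro on the aryl arm

The source may report more compounds than this note shows. Statements on the series, on what has been measured and on what is new or still open speak of the compounds shown alone.

Compound 1, `CC(C)c1ccc(-c2nc(SCc3cn(CC(=O)NC(=O)Nc4ccccn4)nn3)nc(Nc3ccccc3Cl)c2C#N)cc1`, 6790 nM
Compound 2, `COc1ccccc1Nc1nc(SCc2cn(CC(=O)NC(=O)Nc3ccccn3)nn2)nc(-c2ccc(C(C)C)cc2)c1C#N`, 34600 nM
Compound 3, `CC(C)c1ccc(Nc2nc(SCc3cn(CC(=O)NC(=O)Nc4ccccn4)nn3)nc(-c3ccc(C(C)C)cc3)c2C#N)cc1`, 4380 nM

All three compounds were tested in a functional assay on B16-F10 cells (Mus musculus) for inhibition, read by MTT assay, with a stated time of 72 h; on this read-out lower numbers stand for stronger inhibition and higher numbers for weaker inhibition. Compound 3 has the lowest number of the three; it sits within the scatter of compound 1 (a 1.6-fold lower number from compound 1 to compound 3 (0.19 log units; within the scatter)) but well apart from compound 2 (a 7.9-fold lower number from compound 2 to compound 3 (0.90 log units; beyond the scatter)). For the measured compounds named here, the only change that went beyond the scatter on its own was a 5.1-fold higher number from compound 1 to compound 2 (0.71 log units; beyond the scatter).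

Compound 4, `CC(C)c1ccc(Nc2nc(SCc3cn(CC(=O)NC(=O)Nc4ccccn4)nn3)nc(-c3ccc(Cl)cc3)c2C#N)cc1`, has not yet been measured. It differs from compound 3 by chloro in place of isopropyl on an aromatic carbon. Going by the values given here, every measured step so far concerns the group on the nitrogen of the shared core, whereas this change sits on the other aryl ring, the one bound to a carbon of the core. Among the compounds with values here, no measured step therefore bears directly on it, and the data give no ground to expect a shift in either direction.

For compound 4 the expected result in this assay is 5500 nM, with a range of 1800 nM to 16000 nM, which amounts to an estimated step of a 1.3-fold higher number from compound 3 to compound 4 (0.10 log units; within the scatter).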

Compound 4, half-maximal inhibitory concentration: 1590 nM
Compound 4: middle estimate off by 3.5-fold (0.54 log units), on the high side, outside the stated range (below it).
By their numbers in this assay, from the lowest: compound 4; then compounds 3 and 1 (each within the scatter of the next); then compound 2.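

For the compounds shown here, the step from isopropyl to chloro is the first measured change on this aryl ring, and in this assay it gives a 2.8-fold lower number from compound 3 to compound 4 (0.44 log units; beyond the scatter), so the number responds to this ring as well as to the group on the nitrogen of the shared core. The change sits on a six-membered aromatic ring of carbon only, para to a large group, and replaces a group of three carbon atoms with a single chlorine atom; in this pair, the smaller group by heavy-atom count goes with the lower number, meaning stronger inhibition. No measurement here explains why the number falls with this swap.

As far as these compounds go, this finding rests on a single pair of compounds, so it remains open whether the same swap would lower the number with 2-chlorophenyl or 2-methoxyphenyl on the nitrogen instead of 4-isopropylphenyl. Also open, from the compounds shown here alone, is what a methoxy group, an amine, a carboxylic acid or a longer alkyl chain would do at this same place on the ring.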